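A Second Chlorine on the Only Measured Compound

The compounds below may be only part of what the source reports. "The series", "measured", "known", "first", "only" and "open" are said of these compounds alone.

Going by the values given here, compound 3 (`CC(C)(C)C1=NN(c2ccc(Cl)cc2)C(c2ccc(Cl)cc2)C1`) is the only compound with a number so far. In a functional assay on NCI-H1299 cells (Homo sapiens) for cytotoxicity, read by a luciferase reporter and CellTiter-Glo, with a stated time of 72 h (a higher number here means a weaker inhibitor, a lower number a stronger inhibitor), compound 3 gives 19300 nM and stands alone, with nothing to rank it against. Two relatives offer no help: in this assay compound 1 (`COc1cccc(C2=NN(c3ccc(Cl)cc3)C(c3ccc(Cl)cc3)C2)c1`) shows "not determined" (no result reported) as its entry and compound 2 (`CC(C)(C)C1=NN(c2ccc(Cl)cc2)C(c2ccc(-c3ccccc3)cc2)C1`) shows "not determined" (no result reported) as its entry.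

Compound 4 (`CC(C)(C)C1=NN(c2ccc(Cl)cc2)C(c2ccc(Cl)c(Cl)c2)C1`) turns the 4-chlorophenyl of compound 3 into a 3,4-dichlorophenyl: chloro in place of hydrogen on an aromatic carbon is the whole change. The new chloro group sits ortho to the existing chloro group.

Among the compounds with values here, no measured pair shows what such a change does here, so only a small shift is expected in this assay and it may stay within the usual scatter. The direction is a tentative lean toward a stronger inhibitor. The expected change is a 1.5-fold lower number from compound 3 to compound 4 (0.17 log units; within the scatter) and remains a cautious guess. For compound 4 the estimated value is 13000 nM with an expected range from 5000 nM to 32000 nM in this test.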

Compound 4, half-maximal inhibitory concentration: 14800 nM
For compound 4 the middle estimate is 1.1-fold (0.06 log units) below the measured one, within the range that was stated.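

Going by these compounds alone, with a second chloro group on the ring, the pair gives the first measured step in this assay, and it reads a 1.3-fold lower number from compound 3 to compound 4 (0.12 log units; within the scatter). A chloro group in place of hydrogen at this position, ortho to a chloro group, therefore leaves compound 4 and its parent indistinguishable in this test, and the 3,4-dichlorophenyl compound stays in the same range of values as the 4-chlorophenyl one. No accompanying measurement offers a reason for this result.

This single step covers only one substituent at one position, so it cannot show whether the position responds to other groups. An amine or a carboxylic acid at the same carbon might give a step beyond the scatter, or it might not, and the compounds shown cannot settle that.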